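Second methyl added to compound 2

The compounds below may be only part of what the source reports. "The series", "measured", "known", "first", "only" and "open" are said of these compounds alone.

For the measured compounds named here, compound 2 `CCCN(CCC)c1cc(C)nc2c(-c3ccc(N(C)C)nc3C)c(C)nn12` stands alongside compound 1 `CCCN(CCC)c1cc(C)nc2c(-c3ccc(N(C)C)nc3)c(C)nn12`, the only other measured compound; in an assay on CHO cells for binding affinity to corticotropin-releasing factor receptor 1 (Homo sapiens) (a lower number here means a stronger inhibitor, a higher number a weaker inhibitor), compound 2 gives 190 nM and compound 1 gives 110 nM. Going by the values given here, the step of a 1.7-fold higher number from compound 1 to compound 2 (0.24 log units; within the scatter) is the one measured change of the same kind. Compound 3 `CCCN(CCC)c1cc(C)nc2c(-c3c(C)cc(N(C)C)nc3C)c(C)nn12` differs from compound 2 by methyl in place of hydrogen on an aromatic carbon. Among the compounds with values here, since the one comparable step stayed within the scatter, a small shift toward a higher number, if any, is expected in this assay. For compound 3 the expected value is 260 nM, within 130 nM to 600 nM. The expected step is a 1.4-fold higher number from compound 2 to compound 3 (0.14 log units; within the scatter).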

Compound 3, half-maximal inhibitory concentration: 40 nM
Estimate against measurement, compound 3: 6.5-fold (0.81 log units) above; measured number below the stated range.
By their numbers in this assay, from the lowest: compound 3; then compounds 1 and 2 (each within the scatter of the next).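

In this assay, methyl in place of hydrogen on the aromatic carbon opposite the ring nitrogen gives a 4.8-fold lower number from compound 2 to compound 3 (0.68 log units; beyond the scatter), beyond the scatter. The same kind of change at the other ring position gave a 1.7-fold higher number from compound 1 to compound 2 (0.24 log units; within the scatter), so across these two steps the outcome depends on where the methyl sits on this ring. No available measurement bears on the reason for this drop.

Still open, from the compounds shown here alone, is whether this methyl gives a similar step without the methyl added in compound 2. Also open, going by these compounds, is whether ethyl, methoxy or chlorine at this place would match methyl.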